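Carboxy for hydroxy on two cores, one step known

The compounds below may be only part of what the source reports. "The series", "measured", "known", "first", "only" and "open" are said of these compounds alone.

Compound 1 `CCOc1ccc2nc(C(=O)Nc3c(F)cc(-c4cccc(F)c4)cc3F)c(C)c(O)c2c1` gives 2.96% in a functional assay on A-375 cells (Homo sapiens) for antiproliferative activity, read by MTT assay, with a stated time of 24 h, tested at 1.23 ug/mL; a higher number here means a stronger effect of the compound at the concentration tested, a lower number a weaker effect. Compound 3 `CCOc1ccc2nc(C(=O)Nc3c(F)cc(-c4cccc(F)c4)cc3F)c(C)c(C(=O)O)c2c1` gives 26.7% in this assay. The change carboxy in place of hydroxy on an aromatic carbon brings a number 23.7 percentage points higher from compound 1 to compound 3 (beyond the scatter). Compound 2 `COc1ccc2nc(C(=O)Nc3ccc(-c4ccccc4)cc3)c(C)c(O)c2c1` gives 18.7% in this assay; the difference between the core of compound 2 and the core of compound 1 is not broken down here. Compound 4 `COc1ccc2nc(C(=O)Nc3ccc(-c4ccccc4)cc3)c(C)c(C(=O)O)c2c1` is not yet measured and differs from compound 2 by carboxy in place of hydroxy on an aromatic carbon, the same change at a place described in the same words as before. Within the data shown here, only one instance of the change has been measured, so the expectation carries wide margins. A step of about a number 17.3 percentage points higher from compound 2 to compound 4 (beyond the scatter) is expected, because the earlier instance gave a number 23.7 percentage points higher from compound 1 to compound 3 (beyond the scatter) on the other core. Compound 4 is accordingly estimated at 36% in this assay, most likely between 16% and 56%.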

Compound 4, a percentage reported as inhibition, at one concentration (the size of the read-out at that concentration, not a potency): 21.3%
For compound 4 the middle estimate is 14.7 percentage points above the measured one; measured number inside the range.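

In this assay, carboxy in place of hydroxy on an aromatic carbon brings a number 2.6 percentage points higher from compound 2 to compound 4 (within the scatter), so the size of the step does not carry from the core of compound 1 to the core of compound 2: the same change on two cores in this assay, a number 23.7 percentage points higher (beyond the scatter) from compound 1 to compound 3 and a number 2.6 percentage points higher (within the scatter) from compound 2 to compound 4, 21.1 percentage points apart, beyond the scatter of two such steps

The step therefore depends on the core in this pair of instances, at a single tested concentration. It does not show which difference between the two cores matters, as they differ in several places at once, and two instances give no general rule for the series.

Open, from the compounds shown here alone, is how an amine or a primary amide would compare with hydroxy and carboxy at this place. Also open, going by these compounds, is what the ethoxy group and the fluorine atoms each contribute when changed alone.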